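This account rests on a few compounds, and the source may have more. Where it says the series, first, only, none or still open, it means among the compounds named here.

Compound 1 `CCN(CC)c1nc(-c2ccccc2)c(Cc2c(O)ccc3ccccc23)c(=O)[nH]1` gives 155000 nM in a functional assay on RT-112 cells (Homo sapiens) for antiproliferative activity, read by MTT assay, with a stated time of 24 h; a higher number here means a weaker inhibitor, a lower number a stronger inhibitor.
Compound 2 `O=c1[nH]c(NCCO)nc(-c2ccccc2)c1Cc1c(O)ccc2ccccc12` gives 96600 nM in this assay.
Compound 3 `COc1ccc(Nc2nc(-c3ccccc3)c(Cc3c(O)ccc4ccccc34)c(=O)[nH]2)cc1` gives 138000 nM in this assay.

All three share one core and differ only in the group attached to one aromatic carbon of that core. Compound 3 stands second highest of the three numbers, yet no gap sets it apart from the others: a 1.1-fold lower number from compound 1 to compound 3 (0.05 log units; within the scatter), and a 1.4-fold higher number from compound 2 to compound 3 (0.15 log units; within the scatter). In other words, the three compounds sit together within the usual scatter.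

Compound 4 `O=c1[nH]c(Nc2ccc(O)cc2)nc(-c2ccccc2)c1Cc1c(O)ccc2ccccc12` has not yet been measured. It differs from compound 3 in one place: hydrogen in place of methyl on an oxygen on an aromatic ring. Going by the values given here, no measured step strips a methyl from an oxygen in this way, so the closest guidance comes from the exchanges at the same carbon of the core, a 1.6-fold lower number from compound 1 to compound 2 (0.21 log units; within the scatter), a 1.1-fold lower number from compound 1 to compound 3 (0.05 log units; within the scatter) and a 1.4-fold higher number from compound 2 to compound 3 (0.15 log units; within the scatter), each of them within the scatter even though whole groups were swapped. A much smaller change is therefore expected to leave this assay essentially where it is, and the expected step is a 1.1-fold lower number from compound 3 to compound 4 (0.04 log units; within the scatter). For compound 4 the estimate in this assay is 125000 nM, with a range from 60000 nM to 260000 nM.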

Compound 4, half-maximal inhibitory concentration: 265000 nM
For compound 4 the middle estimate is 2.1-fold (0.33 log units) below the measured one, outside the stated range (above it).
By their numbers in this assay, from the lowest: compounds 2, 3, 1 and 4 (each within the scatter of the next, the first and the last beyond it).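

In this assay, taking the methyl off the oxygen of the 4-methoxyphenyl group is a small edit, and its step stays within the scatter (a 1.9-fold higher number from compound 3 to compound 4 (0.28 log units; within the scatter)), as does the exchange of diethylamino for (4-hydroxyphenyl)amino (a 1.7-fold higher number from compound 1 to compound 4 (0.23 log units; within the scatter)). Going by these compounds alone, what the earlier compounds did not show is a step beyond the scatter: replacing 2-hydroxyethyl with 4-hydroxyphenyl on the nitrogen gives one, though a modest one (a 2.7-fold higher number from compound 2 to compound 4 (0.44 log units; beyond the scatter)), whereas replacing it with 4-methoxyphenyl did not (a 1.4-fold higher number from compound 2 to compound 3 (0.15 log units; within the scatter)). The group at this place can therefore shift the number a little, but compound 3 and compound 4 remain within the scatter of each other, and nothing available explains the gap.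

On these data alone, it remains open whether an amine or a carboxylic acid in place of the hydroxy on the aromatic ring, or a longer chain in place of 2-hydroxyethyl, would move the number further. All four compounds also keep the same shared core, so they leave open how changes elsewhere on it would read.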